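A few compounds are considered here, and "the series" means these few. Any claim that something is new, unique, unknown or untested is made for them only; others in the source may bear on it.

Working notes on the series. The common core is that of compound 1 `Nc1nc(-c2ccc(Cl)cc2)c(CC(=O)O)s1`, which carries an amino group where the other members carry a large group. In an in vitro assay on HEK385-7 cells for displacement of a labelled ligand from prostaglandin D2 receptor 2 (Homo sapiens) (on this read-out lower numbers stand for stronger inhibition and higher numbers for weaker inhibition), compound 1 gives only a limit of the assay and no number, > 100000 nM (the limit of > 100000 nM in this assay, at which 1 of the 3 values shown sits). Compound 2 `COc1ccc(C(c2ccccc2)c2nc(-c3ccc(Cl)cc3)c(CC(=O)O)s2)cc1` in this assay gives 8.4 nM. Compound 3 `N#Cc1ccc(-c2nc(C(c3ccc(F)cc3)c3ccc(F)cc3)sc2CC(=O)O)cc1` in this assay gives 150 nM, the highest of the two numbers recorded; its nearest neighbour, compound 2, sits at a lower number by a gap beyond the scatter, but the two structures differ in more than one place, so no single step can be read from the pair.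

Compound 4 `O=C(O)Cc1sc(C(c2ccc(F)cc2)c2ccc(F)cc2)nc1-c1ccnc(N2CCCC2)c1` is not yet measured. It differs from compound 3 as follows: 2-(pyrrolidin-1-yl)pyridin-4-yl in place of 4-cyanophenyl on an aromatic carbon. Within the data shown here, no measured pair isolates a change of this kind, so the expectation rests on compound 3 alone. A modest move to a lower number is expected, a step of a 1.9-fold lower number from compound 3 to compound 4 (0.27 log units; within the scatter) that may not exceed the scatter. For compound 4 in this assay the estimate is 80 nM, with a range from 15 nM to 400 nM.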

Compound 4, half-maximal inhibitory concentration: 230 nM
Compound 4: middle estimate off by 2.9-fold (0.46 log units), on the low side, within the range that was stated.
By their numbers in this assay, from the lowest: compound 2; then compounds 3 and 4 (each within the scatter of the next). At a limit, above all of these: compound 1.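

In this assay, the exchange of 4-cyanophenyl for 2-(pyrrolidin-1-yl)pyridin-4-yl on this aromatic carbon, next to the ring nitrogen, gives a 1.5-fold higher number from compound 3 to compound 4 (0.19 log units; within the scatter). Among these compounds, this is the first single-place step, and it shows that this position accepts the entering group, with its extra ring and without the nitrile, with no change beyond the scatter. Nothing shown accounts for the step or tells which part of either group matters at this position.

From the compounds shown here alone, whether a morpholine or a dimethylamino group in place of the pyrrolidine, or a plain phenyl at this position, would move the number remains open. So does whether the same exchange would read the same with the large group of compound 2 in place of the one shared by compound 3 and compound 4.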